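A few compounds are considered here, and "the series" means these few. Any claim that something is new, unique, unknown or untested is made for them only; others in the source may bear on it.

Series in a functional assay on HCT-116 cells (Homo sapiens) for inhibition, read by MTT assay, with a stated time of 72 h; on this read-out higher numbers stand for weaker inhibition and lower numbers for stronger inhibition:
- compound 1 `COc1ccc(CNCc2c(OC)cc(Oc3cccc(Nc4ccccc4)c3)cc2OC)cc1`: 2620 nM
- compound 2 `COc1cc(Oc2cccc(Nc3ccccc3)c2)cc(OC)c1CN[C@H](C)c1ccccc1`: > 20000 nM (a limit of the assay)
- compound 3 `COc1cc(Oc2cccc(Nc3ccccc3)c2)cc(OC)c1CNCc1ccc(Cl)cc1`: 3310 nM

Compound 3 stands level with compound 1, with a 1.3-fold higher number from compound 1 to compound 3 (0.10 log units; within the scatter). Compound 2 gives only a limit.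

The next change leads to compound 4 `COc1cc(Oc2cccc(Nc3ccccc3)c2)cc(OC)c1CN(C)C`: dimethylamino in place of (4-chlorobenzyl)amino on a saturated chain carbon bound to an aromatic carbon. Swapping the group on the amine nitrogen has moved the numbers, as seen in an at least 7.6-fold higher number from compound 1 to compound 2 (0.88 log units; beyond the scatter) and an at least 6.0-fold lower number from compound 2 to compound 3 (0.78 log units; beyond the scatter). The chloro for methoxy swap, a 1.3-fold higher number from compound 1 to compound 3 (0.10 log units; within the scatter), did not. Among the compounds with values here, no measured compound lacks the aromatic ring on this amine, so the size of the step is uncertain. A modest move towards weaker inhibition is expected in this assay, estimated as a 2.1-fold higher number from compound 3 to compound 4 (0.33 log units; beyond the scatter). For compound 4 the estimate is 7000 nM, with an expected range of 2500 nM to 20000 nM.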

Compound 4, half-maximal inhibitory concentration: 12900 nM
Estimate against measurement, compound 4: 1.8-fold (0.27 log units) below, within the range that was stated.
By their numbers in this assay, from the lowest: compounds 1 and 3 (each within the scatter of the next); then compound 4. At a limit, above all of these: compound 2.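

In this assay, removing the aromatic ring from this amine weakens inhibition: dimethylamino gives a 3.9-fold higher number from compound 3 to compound 4 (0.59 log units; beyond the scatter) and a 4.9-fold higher number from compound 1 to compound 4 (0.69 log units; beyond the scatter). The ring is not sufficient for the stronger values, as compound 2 keeps a ring on this amine and goes against that pattern. The remaining step gives only a floor, an at least 1.5-fold lower number from compound 2 to compound 4 (0.19 log units; that floor lies within the scatter), and its true size stays open: the limit of > 20000 nM in this assay, at which 1 of the 4 values shown sits.

Compound 4 loses both the ring and the hydrogen-bond donor on this nitrogen, and the two changes remain unseparated. Methylamino or N-methylbenzylamino on this carbon would separate them.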